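The source may hold more compounds than are shown below. What is called first, only, known or untested is meant among the compounds shown, and "the series" means these compounds.

Measured in an ADME assay on HepG2 cells (Homo sapiens) for cytotoxicity; a higher number here means that more compound is tolerated, a lower number that less compound is tolerated:
Compound 1 `O=C(N[C@H](/C=C/S(=O)(=O)c1ccccc1)CCc1ccccc1)c1cccc2cccnc12`: > 80000 nM, a limit.
Compound 2 `O=C(N[C@H](/C=C/S(=O)(=O)c1ccccc1)CCc1ccccc1)c1cccc2c1NCCC2`: > 160000 nM, a limit.
Compound 3 `Cc1ncn(C)c1C(=O)N[C@H](/C=C/S(=O)(=O)c1ccccc1)CCc1ccccc1`: 34400 nM.

Among the compounds with values here, compound 3 holds the only true number of the three, and it sits lowest, with the steps reading an at least 2.3-fold lower number from compound 1 to compound 3 (0.36 log units; beyond the scatter) and an at least 4.6-fold lower number from compound 2 to compound 3 (0.66 log units; beyond the scatter). The next structure, compound 4 `O=C(N[C@H](/C=C/S(=O)(=O)c1ccccc1)CCc1ccccc1)[C@@H]1CSCN1`, changes the same place, on a carbonyl carbon: 1,3-thiazolidin-4-yl in place of 1,4-dimethyl-1H-imidazol-5-yl on a carbonyl carbon. Those two steps bear directly on this change. They exchange the group at this place, but each gives only a bound on the size. The remaining step, a step that the two limits leave unreadable from compound 1 to compound 2, adds no size. Neither compound 1 nor compound 2 carries the 1,3-thiazolidin-4-yl group, so they guide direction only weakly. Compound 3 at 34400 nM is the base, and a small rise in this assay is expected, probably not beyond the scatter. The expected change is a 1.5-fold higher number from compound 3 to compound 4 (0.16 log units; within the scatter). For compound 4 the estimate is 50000 nM, with an expected range of 17000 nM to 160000 nM.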

Compound 4, half-maximal cytotoxic concentration: 77800 nM
Estimate against measurement, compound 4: 1.6-fold (0.19 log units) below; low and high end bracket the measured number.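

In this assay, within the data shown here, the step of a 2.3-fold higher number from compound 3 to compound 4 (0.35 log units; beyond the scatter) is the first exact reading at this place on the carbonyl carbon: 1,3-thiazolidin-4-yl, a non-aromatic ring with fewer heavy atoms and a hydrogen-bond donor, is tolerated better than 1,4-dimethyl-1H-imidazol-5-yl. Compounds 1 and 2 stand at limits of the assay, so only floors can be read against them: an at least 2.0-fold lower number from compound 2 to compound 4 (0.31 log units; beyond the scatter) keeps compound 4 under compound 2, whereas an at least 1.0-fold lower number from compound 1 to compound 4 (0.01 log units; that floor lies within the scatter) gives no order for compound 1. No measurement shown gives a cause for the step.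

The change replaces the aromatic ring, adds the ring sulfur and the donor, and introduces a stereocentre all at once, so the data cannot assign the step to any one of these. A pyrrolidin-2-yl group on the same carbonyl carbon would test whether the ring sulfur matters.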